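Aryl ether exchange in the dioxane acid series

The compounds below may be only part of what the source reports. "The series", "measured", "known", "first", "only" and "open" are said of these compounds alone.

Within the data shown here, compound 2 `CSc1ccc(OC(C)(C)C2OCC(C/C=C\CCC(=O)O)C(c3cccnc3)O2)c([N+](=O)[O-])c1` gives the lowest number so far in a functional assay for inhibition, with Homo sapiens as the target (a higher number here means weaker binding, a lower number tighter binding), 4.47 nM. Among the measured compounds shown here, compound 1 `O=C(O)CC/C=C\CC1COC(c2cccc3ccccc23)OC1c1cccnc1` gives 631 nM in this assay, a higher number well beyond the scatter; the two compounds differ in more than one place, so no single step between them is known, and only their two values can be compared. Compound 3 `CC(C)(Oc1ccccc1Br)C1OCC(C/C=C\CCC(=O)O)C(c2cccnc2)O1` has not yet been measured. Against compound 2 its change is a group of 7 heavy atoms (6 carbon, 1 bromine; one six-membered aromatic ring of carbon only) in place of a group of 11 heavy atoms (7 carbon, 1 nitrogen, 2 oxygen, 1 sulfur; one six-membered aromatic ring of carbon only), on an oxygen on a saturated carbon. The entering 2-bromophenyl is a smaller group than the one it replaces and carries no hydrogen-bond acceptors, whereas the leaving group carries three. For the measured compounds named here, with no measured step to lean on, the expectation for compound 3 is a move toward a higher number, a step beyond the usual scatter but not reaching the level of compound 1, estimated from compound 2 to compound 3 as a 6.7-fold higher number from compound 2 to compound 3 (0.83 log units; beyond the scatter). For compound 3 in this assay the expected value is 30 nM, with a range from 6 nM to 200 nM.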

Compound 3, dissociation constant: 63.1 nM
For compound 3 the middle estimate is 2.1-fold (0.32 log units) below the measured one, and the stated range covers the measured number.
By their numbers in this assay, from the lowest: compound 2; then compound 3; then compound 1.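

In this assay, among these compounds, the exchange on an oxygen on a saturated carbon gives a 14-fold higher number from compound 2 to compound 3 (1.15 log units; beyond the scatter), the first reading of a single change, and it shows that the number is sensitive to the group at this place. Both the leaving group and the 2-bromophenyl carry a six-membered aromatic ring of carbon only, so keeping such a ring at this place does not by itself keep compound 3 at the level of compound 2, which gives 4.47 nM. No measurement bears on the reason for this step, so the result records its size and direction but offers no explanation.

The step replaces the nitro and methylthio groups and introduces bromine in one change, so the compounds shown leave open how much of it belongs to each of these groups. Also open, from the compounds shown here alone, is how a phenyl ring carrying only a nitro group, only a methylthio group, or a chlorine in place of the bromine would read in this assay at this same place.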